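Sulfonyl aryl exchange within the sulfonylurea pair

This account rests on a few compounds, and the source may have more. Where it says the series, first, only, none or still open, it means among the compounds named here.

Compound 1 `O=C(NS(=O)(=O)c1cc(Cl)c(Cl)s1)OC/C=C1\CCCc2cnn(Cc3ccc(Cl)cc3Cl)c21` carries a (4,5-dichlorothiophen-2-yl)sulfonyl group on a carbamate; in a functional assay on CHO-K1 cells for antagonist activity at prostaglandin E2 receptor EP3 subtype (Homo sapiens), read by TR-FRET and cAMP accumulation, with a stated time of 30 min (on this read-out lower numbers stand for stronger inhibition and higher numbers for weaker inhibition), compound 1 gives 5 nM. Compound 2 `Cn1cc(S(=O)(=O)NC(=O)NC/C=C2\CCCc3cnn(Cc4ccc(Cl)cc4Cl)c32)cn1` carries a (1-methyl-1H-pyrazol-4-yl)sulfonyl group on a urea, and in this assay compound 2 gives 8 nM; the two numbers lie within the scatter of one another, so compound 2 stands level with compound 1. Compound 3 `O=C(NC/C=C1\CCCc2cnn(Cc3ccc(Cl)cc3Cl)c21)NS(=O)(=O)c1cc(Cl)c(Cl)s1` keeps the urea of compound 2 and takes the change (4,5-dichlorothiophen-2-yl in place of 1-methyl-1H-pyrazol-4-yl on a sulfonyl sulfur). For the measured compounds named here, no measured pair isolates this change, and the two measured compounds sit close together, so no step beyond the scatter is expected in this assay. The step of a 1.6-fold lower number from compound 2 to compound 3 (0.20 log units; within the scatter) is expected to be small. Compound 3 is expected at 5 nM, with a range of 2 nM to 15 nM.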

Compound 3, half-maximal inhibitory concentration: 11 nM
The estimate for compound 3 lay 2.2-fold (0.34 log units) below the measured number, within the range that was stated.
By their numbers in this assay, from the lowest: compounds 1, 2 and 3 (each within the scatter of the next, the first and the last beyond it).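

In this assay, the sulfonyl sulfur of the urea accepts 4,5-dichlorothiophen-2-yl in place of 1-methyl-1H-pyrazol-4-yl with a 1.4-fold higher number from compound 2 to compound 3 (0.14 log units; within the scatter), so the two five-membered aromatic rings stand level here. For the compounds shown here, compounds 1 and 2 differ in two places, so only this pair isolates the change at this position. Nothing measured here gives a reason for this result.

On these data alone, whether a phenyl ring, a cyclopropyl group or an amine on the sulfonyl sulfur would stay level with these two rings remains open.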